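Chain extension of the hydroxamate linker in a Bcl-2 series

The source may report more compounds than this note shows. Statements on the series, on what has been measured and on what is new or still open speak of the compounds shown alone.

Measured so far:
compound 1 `CC1(C)CCC(CN2CCN(c3ccc(C(=O)NS(=O)(=O)c4ccc(NCCCCCC(=O)NO)c([N+](=O)[O-])c4)c(Oc4cnc5[nH]ccc5c4)c3)CC2)=C(c2ccc(Cl)cc2)C1` — 230 nM
compound 2 `CC1(C)CCC(CN2CCN(c3ccc(C(=O)NS(=O)(=O)c4ccc(NCCCCCCC(=O)NO)c([N+](=O)[O-])c4)c(Oc4cnc5[nH]ccc5c4)c3)CC2)=C(c2ccc(Cl)cc2)C1` — 240 nM

In an assay on isolated protein for binding affinity to Apoptosis regulator Bcl-2 (Homo sapiens), read by fluorescence polarization (a higher number here means a weaker inhibitor, a lower number a stronger inhibitor), compound 1 gives 230 nM, and compound 2 gives 240 nM. Compound 2 holds the higher of the two numbers, but its nearest neighbour compound 1 sits within the scatter of it, so no order can be read between them. Compound 3 `CC1(C)CCC(CN2CCN(c3ccc(C(=O)NS(=O)(=O)c4ccc(NCCCCCCCC(=O)NO)c([N+](=O)[O-])c4)c(Oc4cnc5[nH]ccc5c4)c3)CC2)=C(c2ccc(Cl)cc2)C1` carries the same kind of change once more: (hydroxycarbamoyl)methyl in place of hydroxycarbamoyl on a saturated chain carbon, six bonds along the chain from a nitrogen on an aromatic ring. For the measured compounds named here, the only measured step of this kind, a 1.0-fold higher number from compound 1 to compound 2 (0.02 log units; within the scatter), lay within the scatter. The estimated step of a 1.0-fold higher number from compound 2 to compound 3 (0.02 log units; within the scatter) is therefore expected to be no larger than that, in no clear direction. Compound 3 is expected to give 250 nM, within a range of 130 nM to 500 nM.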

Compound 3, half-maximal inhibitory concentration: 250 nM
The estimate for compound 3 equals the measured number at the digits printed; the range from low to high includes it.
By their numbers in this assay, from the lowest: compounds 1, 2 and 3 (each within the scatter of the next).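

Adding one more carbon on this saturated chain, six bonds along from a nitrogen on an aromatic ring, again leaves the number in this assay within the scatter (a 1.0-fold higher number from compound 2 to compound 3 (0.02 log units; within the scatter)). The flat reading now holds over two successive extensions, and the step across both, 2-(hydroxycarbamoyl)ethyl in place of hydroxycarbamoyl, also stays within the scatter (a 1.1-fold higher number from compound 1 to compound 3 (0.04 log units; within the scatter)). No measurement accompanying these values speaks to the reason.

On these data alone, whether a longer chain, or a carboxylic acid or an amine in place of hydroxycarbamoyl, gives a number in this assay outside the scatter of these three compounds stays open.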